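Rearranging the difluorophenyl group of compound 3

A few compounds are considered here, and "the series" means these few. Any claim that something is new, unique, unknown or untested is made for them only; others in the source may bear on it.

In an ADME assay on MT4 cells (Homo sapiens) for cytotoxicity, read by MTT assay (a lower number here means that less compound is tolerated, a higher number that more compound is tolerated), compound 3 (`O=C1c2ccccc2C(=O)N1CCOC(=S)N(C(=O)c1c(F)cccc1F)c1ccc(Cl)cc1`) gives a clear reading (39000 nM). Compound 1 (`O=C1c2ccccc2C(=O)N1CCOC(=S)N(C(=O)c1ccccc1[N+](=O)[O-])c1ccc(Cl)cc1`) gives a reading (21000 nM) that lies close to it, and the step between them stays within the scatter (a 1.9-fold higher number from compound 1 to compound 3 (0.27 log units; within the scatter)). Compound 2 (`O=C1c2ccccc2C(=O)N1CCOC(=S)N(C(=O)c1ccc([N+](=O)[O-])cc1)c1ccc(Cl)cc1`) gives only a limit of this assay and not a number (> 100000 nM).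

Compound 4 (`O=C1c2ccccc2C(=O)N1CCOC(=S)N(C(=O)c1cc(F)cc(F)c1)c1ccc(Cl)cc1`) has the same atoms as compound 3, with 3,5-difluorophenyl in place of 2,6-difluorophenyl on a carbonyl carbon. The closest measured parallel is 4-nitrophenyl in place of 2-nitrophenyl, which also rearranges a group on its ring and gave a clear step (an at least 4.7-fold higher number from compound 1 to compound 2 (0.67 log units; beyond the scatter)). That step ends at a limit and involves a nitro group rather than fluorines, so it is only a loose guide. A smaller move in the same direction is therefore expected (a 1.7-fold higher number from compound 3 to compound 4 (0.22 log units; within the scatter)), and it may not clear the scatter. The estimated value for compound 4 is about (65000 nM), with an expected range (28000 nM to 100000 nM).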

Compound 4, half-maximal cytotoxic concentration: 59000 nM
Compound 4: the middle estimate sits 1.1-fold (0.04 log units) above what was measured; low and high end bracket the measured number.
By their numbers in this assay, from the lowest: compounds 1, 3 and 4 (each within the scatter of the next, the first and the last beyond it). At a limit, above all of these: compound 2.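

Rearranging the two fluorines, from 2,6-difluorophenyl to 3,5-difluorophenyl on a carbonyl carbon, gives no change that can be told apart in this assay (a 1.5-fold higher number from compound 3 to compound 4 (0.18 log units; within the scatter)), whereas the rearranged nitrophenyl pair gave a step beyond the scatter. Even so, 3,5-difluorophenyl separates from 2-nitrophenyl (a 2.8-fold higher number from compound 1 to compound 4 (0.45 log units; beyond the scatter)), which 2,6-difluorophenyl did not do. Compound 2 stands at a limit and not at a number, so the remaining step gives only a floor (an at least 1.6-fold lower number from compound 2 to compound 4 (0.22 log units; that floor lies within the scatter)) that does not settle the order of the two: (the limit of > 100000 nM in this assay, at which 1 of the 4 values shown sits).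

Open, from the compounds shown here alone, is whether a single fluorine, a methoxy group or an amine on this phenyl ring would move the reading beyond the scatter from compound 3. Going by these compounds, how far past its limit compound 2 lies also stays open.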